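The source may report more compounds than this note shows. Statements on the series, on what has been measured and on what is new or still open speak of the compounds shown alone.

Compounds measured in a functional assay on HepG2 cells (Homo sapiens) for cytotoxicity, with a stated time of 72 h; on this read-out lower numbers stand for an effect already at smaller amounts and higher numbers for an effect only at larger amounts of compound:
- Compound 1 `C=C[C@@](C)(/C=C/c1ccc(O)c(/C=C/C(=O)c2ccccc2)c1)CCC=C(C)C`: > 52000 nM
- Compound 2 `C=C[C@@](C)(/C=C/c1ccc(O)c(/C=C/C(=O)NCc2ccc(C(F)(F)F)cc2)c1)CCC=C(C)C`: > 52000 nM

Both entries are limits of the assay and not numbers. Compound 1 stands at the limit of > 52000 nM in this assay, at which 2 of the 2 values shown sit, so it offers a lower bound only. Among the compounds with values here, no measured step connects any two compounds.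

Compound 3 `C=C[C@@](C)(/C=C/c1ccc(O)c(/C=C/c2ccc(F)cc2)c1)CCC=C(C)C` is the next to be read. It carries 4-fluorophenyl in place of benzoyl on a double-bonded chain carbon bound to a double-bonded chain carbon.

The shared core with its phenol and side chain is kept. No step beyond the scatter is expected in this assay, and no direction is favoured, so the expected result is an at least 1.0-fold lower number from compound 1 to compound 3 (0.01 log units; that floor lies within the scatter). A further limit is a likely outcome. Compound 3 is estimated at 50000 nM, with an expected range of 20000 nM to 100000 nM.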

Compound 3, half-maximal effective concentration: > 52000 nM
Compound 3 ended at the assay's limit; the forecaster's own chance of this, stated with the estimate: 65%; at least 1.0-fold (0.01 log units) between middle value and limit.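

Compound 3, like compound 1, gives only a limit in this assay, so no step can be read from compound 1 to compound 3: the limit of > 52000 nM in this assay, at which 3 of the 3 values shown sit. The compounds shown leave open how benzoyl and 4-fluorophenyl compare in this assay, and at what concentration either compound has an effect.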